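The source may hold more compounds than are shown below. What is called first, only, known or untested is meant among the compounds shown, and "the series" means these compounds.

Measured compounds:
compound 1 `CCCOC(=O)c1c(NC(=O)N2CCN(C)CC2)sc2c1CCC2` gives 14200 nM in an assay on cells for agonist activity at Toll-like receptor 2 (Homo sapiens), with a stated time of 24 h; on this read-out lower numbers stand for an effect already at smaller amounts and higher numbers for an effect only at larger amounts of compound;
compound 2 `CC(C)OC(=O)c1c(NC(=S)N2CCN(C)CC2)sc2c1CCC2` gives 16400 nM in this assay.

Of the two numbers, compound 2 has the highest, and its nearest neighbour, compound 1, lies within the scatter of it, so the two compounds cannot be told apart on this read-out. The unmeasured compound 3 `CC(=O)N1CCN(C(=S)Nc2sc3c(c2C(=O)OC(C)C)CCC3)CC1` differs from compound 2 in one place: acetyl in place of methyl on an amine nitrogen in a ring. Among the compounds with values here, no step between measured compounds covers this change, so there is no precedent here to lean on. The expected step from compound 2 to compound 3 in this assay is a 1.5-fold higher number from compound 2 to compound 3 (0.18 log units; within the scatter), a modest move toward a higher number, though a result within the scatter would not surprise. For compound 3 the estimate is 25000 nM, with a range from 8000 nM to 80000 nM.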

Compound 3, half-maximal effective concentration: "not active" (no number reported)
Compound 3 has no reported number here, so the estimate cannot be set against anything.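

Within the data shown here, compound 3 is reported as not active in this assay with no number, so no step from compound 2 to compound 3 can be read. Nothing available here bears on this result. The compounds shown leave open how large any change from methyl to acetyl on an amine nitrogen in a ring would be on this read-out.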